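Replacing a carbamoyl group on a fused two-ring core

The source may hold more compounds than are shown below. What is called first, only, known or untested is meant among the compounds shown, and "the series" means these compounds.

Measured compounds:
compound 1, `Cc1nc2c(OCc3ccccc3)cccn2c1C(N)=O`, 2%
compound 2, `CCOCc1c(C)nc2c(OCc3ccccc3)cccn12`, 35%
not yet measured: compound 3, `Cc1nc2c(OCc3ccccc3)cccn2c1CS(C)(=O)=O`

Going by the values given here, in a functional assay on the whole organism (stomach) for inhibition, with Canis familiaris (Canis lupus familiaris) as the target, at a dose of 5 mg/kg by the intravenous route (a higher number here means a stronger effect of the compound at the dose given, a lower number a weaker effect), compound 1 gives 2%, the lowest of the two numbers known here; compound 2 gives 35%. Among the compounds with values here, the single measured step, a number 33 percentage points higher from compound 1 to compound 2 (beyond the scatter), shows that exchanging the carbamoyl group for another small side chain on the same aromatic carbon went with a large gain in inhibition. Compound 3 makes a related exchange on that carbon: (methylsulfonyl)methyl in place of carbamoyl on an aromatic carbon. Within the data shown here, both the group that enters in compound 2 and the one that enters in compound 3 lack the hydrogen-bond donor of the carbamoyl group, so the step from compound 1 to compound 2 is the one that bears on this case. A rise beyond the scatter is therefore expected, estimated as a number 18 percentage points higher from compound 1 to compound 3 (beyond the scatter), though the entering group differs from the ethoxymethyl of compound 2 and the size is uncertain. Compound 3 is expected to reach about 20%, within 2% to 45%.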

Compound 3, a percentage reported as inhibition, in the whole organism at one dose (the size of the read-out at that dose, not a potency): 0%
The estimate for compound 3 lay 20 percentage points above the measured number; measured number outside the range, below it.
By their numbers in this assay, from the lowest: compounds 3 and 1 (each within the scatter of the next); then compound 2.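

In this assay, the step of a number 2 percentage points lower from compound 1 to compound 3 (within the scatter) shows that removing the hydrogen-bond donor of carbamoyl does not by itself go with a gain in inhibition at this aromatic carbon. What enters matters as well: the step of a number 35 percentage points lower from compound 2 to compound 3 (beyond the scatter) comes from a single exchange, methylsulfonyl in place of ethoxy on the saturated chain carbon bound to that aromatic carbon. Among these three compounds, then, only the ethoxymethyl side chain of compound 2 stands apart, while carbamoyl and (methylsulfonyl)methyl give numbers within the scatter of each other.

From the compounds shown here alone, it remains open whether a longer ether chain, a plain propyl chain, an aminomethyl group or a carboxylic acid on this carbon would side with ethoxymethyl or with the other two. Nothing available here accounts for the gap between ethoxymethyl and (methylsulfonyl)methyl.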